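Aryl amide variation on a shared quinazoline-type anilide series

A few compounds are considered here, and "the series" means these few. Any claim that something is new, unique, unknown or untested is made for them only; others in the source may bear on it.

For the measured compounds named here, compound 1 `O=C(CSc1nc(Nc2ccccc2)c2ccccc2n1)Nc1ccccc1Cl` carries a 2-chlorophenyl on the amide-type nitrogen and, in a functional assay on PC-3 cells (Homo sapiens) for inhibition, read by MTT assay, with a stated time of 72 h (on this read-out lower numbers stand for stronger inhibition and higher numbers for weaker inhibition), compound 1 gives 14600 nM, the highest of the three numbers measured so far. Compound 2 `O=C(CSc1nc(Nc2ccccc2)c2ccccc2n1)Nc1ccc(Cl)cc1` gives 12900 nM and compound 3 `O=C(CSc1nc(Nc2ccccc2)c2ccccc2n1)Nc1ccc(C(F)(F)F)cc1` gives 10400 nM; the steps of a 1.1-fold lower number from compound 1 to compound 2 (0.05 log units; within the scatter), a 1.4-fold lower number from compound 1 to compound 3 (0.15 log units; within the scatter) and a 1.2-fold lower number from compound 2 to compound 3 (0.09 log units; within the scatter) all stay within the scatter. Compound 4 `O=C(CSc1nc(Nc2ccccc2)c2ccccc2n1)Nc1ccc(Cl)c(Cl)c1` differs from compound 1 in this way: 3,4-dichlorophenyl in place of 2-chlorophenyl on an amide-type nitrogen. The step of a 1.1-fold lower number from compound 1 to compound 2 (0.05 log units; within the scatter) is the one that bears on it, since both replace the 2-chlorophenyl with a 4-chloro-bearing ring, and it showed no movement beyond the scatter. Compound 4 is therefore expected to give 11000 nM, within 5000 nM to 25000 nM, an expected step of a 1.3-fold lower number from compound 1 to compound 4 (0.12 log units; within the scatter).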

Compound 4, half-maximal inhibitory concentration: 12100 nM
Compound 4: middle estimate off by 1.1-fold (0.04 log units), on the low side; the measured number falls inside the stated range.
By their numbers in this assay, from the lowest: compounds 3, 4, 2 and 1 (each within the scatter of the next).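

In this assay, chloro in place of hydrogen on the ring of compound 2 gives a 1.1-fold lower number from compound 2 to compound 4 (0.03 log units; within the scatter) and so adds no readable shift to the 4-chlorophenyl result. On the amide-type nitrogen, 3,4-dichlorophenyl also stays within the scatter of the other two aryl groups, with a 1.2-fold lower number from compound 1 to compound 4 (0.08 log units; within the scatter) and a 1.2-fold higher number from compound 3 to compound 4 (0.07 log units; within the scatter), so all four compounds now sit level at this position. No measured evidence bears on why this position stays so flat.

Still open, going by these compounds, is whether an amine or a carboxylic acid on this ring would give a step beyond the scatter.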